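Compound 2 to compound 3: one more ring methyl

This account rests on a few compounds, and the source may have more. Where it says the series, first, only, none or still open, it means among the compounds named here.

In a functional assay (plasma) for inhibition, with Canis familiaris (Canis lupus familiaris) as the target (on this read-out lower numbers stand for stronger inhibition and higher numbers for weaker inhibition), compound 1 `CC(=O)N[C@@H]1CSSC(C)(C)[C@H](C(N)=O)NC(=O)[C@H](CC(=O)O)NC(=O)CNC(=O)[C@H](CCCN=C(N)N)NC1=O` gives 20300 nM; 4120 nM (2 entries), and the several entries of compound 1 in this assay, 20300 nM; 4120 nM (2 entries) shows how loosely that compound is placed. Among the measured compounds shown here, compound 2 `CC(=O)N[C@@H]1CSSC(C)(C)[C@H](C(N)=O)NC(=O)[C@@H](CC(=O)O)N(C)C(=O)CNC(=O)[C@@H](CCCN=C(N)N)NC1=O` gives 137000 nM, the only single number in the set. That value is higher than both entries of compound 1, so compound 2 is the weaker inhibitor on the numbers shown.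

Compound 3 `CC(=O)N[C@@H]1CSSC(C)(C)[C@H](C(N)=O)NC(=O)[C@@H](CC(=O)O)N(C)C(=O)CNC(=O)[C@@H](CCCN=C(N)N)N(C)C1=O` carries one further change: methyl in place of hydrogen on an amide-type nitrogen in a ring. This is methyl in place of hydrogen on an amide-type nitrogen in a ring, on the nitrogen next to the ring atom that bears a group of 7 heavy atoms and two ring bonds from the ring atom that bears an acetamido group.

For the measured compounds named here, no measured step isolates this change, so the expectation is loose. Compound 2 at 137000 nM is the only anchor, and a small shift toward weaker inhibition in this assay is expected, perhaps none beyond the scatter. The expected change is a 1.8-fold higher number from compound 2 to compound 3 (0.26 log units; within the scatter). The estimated value for compound 3 is 250000 nM, with an expected range from 70000 nM to 800000 nM.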

Compound 3, half-maximal inhibitory concentration: 23400 nM
Beside the measured number, compound 3's estimate is 11-fold (1.03 log units) above it; the whole stated range lies above it.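

In this assay, methyl in place of hydrogen on the amide-type nitrogen in the ring, next to the ring atom that bears a group of 7 heavy atoms, gives a 5.9-fold lower number from compound 2 to compound 3 (0.77 log units; beyond the scatter). Among the compounds shown here, this is the first step that isolates a single change, and it shows that this ring nitrogen tolerates a methyl: the number moves toward stronger inhibition, and inhibition is not lost. The step rests on one number at each end, and repeat entries for a single compound in this assay can lie far apart, so its size is less firm than its direction, and even the direction is not secure: the several entries of compound 1 in this assay, 20300 nM; 4120 nM (2 entries).

Still open, from the compounds shown here alone, is whether the gain belongs to methyl in particular or extends to a larger group on the same nitrogen, such as ethyl, a longer chain or benzyl. The compounds shown also leave open whether this methyl has the same effect without the other ring methyl present in compound 2 and compound 3, and they give no reason for the shift.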